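Carboxy to ethoxycarbonyl at the limit of the assay

The source may hold more compounds than are shown below. What is called first, only, known or untested is meant among the compounds shown, and "the series" means these compounds.

In a functional assay on HCT-116 cells (Homo sapiens) for cytotoxicity, read by MTT assay, with a stated time of 72 h (a higher number here means that more compound is tolerated, a lower number that less compound is tolerated), compound 1 (`Cn1c(=O)c(C(=O)O)c(O)c2cc(Cc3ccccc3)ccc21`) gives > 10000 nM, which is a limit and not a number. Compound 2 (`Cn1c(=O)c(C(=O)O)c(O)c2cc(Cc3ccc(F)cc3)ccc21`) gives > 10000 nM, also only a limit. Compound 3 (`CCCCCn1c(=O)c(C(=O)O)c(O)c2cc(Cc3ccc(F)cc3)ccc21`) gives > 10000 nM, again a limit. Compound 2 therefore has no exact number of its own, and neither of its two companions supplies one.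

Compound 4 (`CCOC(=O)c1c(O)c2cc(Cc3ccc(F)cc3)ccc2n(C)c1=O`) differs from compound 2 by ethyl in place of hydrogen on an oxygen next to a carbonyl group, which also reads as carboxy to ethoxycarbonyl. The two measured changes are a step that the two limits leave unreadable from compound 1 to compound 2 and a step that the two limits leave unreadable from compound 2 to compound 3. Both leave the carboxy group untouched and neither has a readable size, and the series shows only (the limit of > 10000 nM in this assay, at which 3 of the 3 values shown sit). Among the compounds with values here, with no sized step to draw on, no change beyond the scatter is expected in this assay, in either direction, and another limit is the likeliest report. The expected move is a step that the limit leaves unreadable from compound 2 to compound 4. Compound 4 is estimated at 20000 nM, within an expected range of 5000 nM to 60000 nM.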

Compound 4, half-maximal cytotoxic concentration: > 10000 nM
Compound 4: a limit, no number (the forecaster's own chance of this, stated with the estimate: 80%); the middle value lies beyond the limit too.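

In this assay, within the data shown here, compound 4 gives > 10000 nM, which is a limit and not a number, and compound 2 also has only a limit, so no step between them can be read. The compounds shown leave open how far any of these changes moves the half-maximal cytotoxic concentration, as the series still shows only: the limit of > 10000 nM in this assay, at which 4 of the 4 values shown sit.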